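Adding amino to the 4-methoxyphenyl ring of compound 3

This account rests on a few compounds, and the source may have more. Where it says the series, first, only, none or still open, it means among the compounds named here.

Values in a functional assay on HT-29 cells (Homo sapiens) for antiproliferative activity, read by MTT assay, with a stated time of 72 h; on this read-out lower numbers stand for stronger inhibition and higher numbers for weaker inhibition:
Compound 1 `COc1cc(-c2nccn2C)cc(OC)c1OC`: > 100000 nM
Compound 2 `COc1ccc(-n2ccnc2-c2cc(OC)c(OC)c(OC)c2)cc1[N+](=O)[O-]`: 600 nM
Compound 3 `COc1ccc(-n2ccnc2-c2cc(OC)c(OC)c(OC)c2)cc1`: 13100 nM

The entry for compound 1 is a limit of the assay, not a number. Of the two actual numbers, compound 3 holds the higher and compound 2 the lower. The next change is amino in place of hydrogen on an aromatic carbon, giving compound 4 `COc1ccc(-n2ccnc2-c2cc(OC)c(OC)c(OC)c2)cc1N`. The step that bears on it most directly is the large one a 22-fold higher number from compound 2 to compound 3 (1.34 log units; beyond the scatter), with hydrogen replacing nitro on that same carbon. The step of an at least 7.6-fold lower number from compound 1 to compound 3 (0.88 log units; beyond the scatter) lies elsewhere in the structure and bears on it little. Amino is not nitro, so the transfer is uncertain, but a large step to a lower number is expected in this assay. The expected step is a 26-fold lower number from compound 3 to compound 4 (1.42 log units; beyond the scatter). Compound 4 is estimated at 500 nM, with an expected range of 50 nM to 5000 nM.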

Compound 4, half-maximal inhibitory concentration: 200 nM
Compound 4: the middle estimate sits 2.5-fold (0.40 log units) above what was measured, within the range that was stated.
By their numbers in this assay, from the lowest: compound 4; then compound 2; then compound 3. At a limit, above all of these: compound 1.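

In this assay, amino in place of hydrogen on this aromatic carbon, ortho to a methoxy group, gives a 66-fold lower number from compound 3 to compound 4 (1.82 log units; beyond the scatter) and so shows that a lower number at this position is not tied to nitro. Amino also improves on nitro at this carbon, with a 3.0-fold lower number from compound 2 to compound 4 (0.48 log units; beyond the scatter) on the same core. On these data alone, whether a methylamino, dimethylamino or acetamido group on this carbon keeps the lower number remains open. Nothing shown here gives a cause for either step.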